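The compounds below may be only part of what the source reports. "The series", "measured", "known", "first", "only" and "open" are said of these compounds alone.

Within the data shown here, in an assay on membranes from liver for displacement of a labelled ligand from Sigma intracellular receptor 2 (Rattus norvegicus), read by scintillation counting (a lower number here means a stronger inhibitor, a higher number a weaker inhibitor), compound 1 `c1ccc([C@@H]2CCC[C@H](CCNCC3CCCCC3)O2)cc1` gives 36 nM, the lowest of the two numbers so far; compound 2 `c1ccc([C@@H]2CCC[C@H](CCN3CCCC3)O2)cc1` gives 170 nM in this assay, a gap beyond the scatter. Compound 3 `c1ccc([C@H]2CCC[C@@H](CCNCC3CCCCC3)O2)cc1` is the mirror image of compound 1: the two compounds have the same atoms and bonds and differ only in configuration as drawn: 2 of 2 stereo elements differ (all stereocentres are inverted: mirror images); a stereocentre at a saturated ring carbon is drawn S in compound 1 and R in compound 3; a stereocentre at a saturated ring carbon is drawn R in compound 1 and S in compound 3. Among the measured compounds shown here, no measured pair shows what inverting both stereocentres does in this assay, so nothing in the numbers speaks to the size of this step. A modest move toward a weaker inhibitor is expected, a 2.8-fold higher number from compound 1 to compound 3 (0.44 log units; beyond the scatter), as one enantiomer usually trails the other. Compound 3 is thus estimated at about 100 nM in this assay, within 25 nM to 400 nM.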

Compound 3, inhibition constant: 57 nM
Beside the measured number, compound 3's estimate is 1.8-fold (0.24 log units) above it, and the stated range covers the measured number.
By their numbers in this assay, from the lowest: compounds 1 and 3 (each within the scatter of the next); then compound 2.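

In this assay the inversion of both stereocentres gives a 1.6-fold higher number from compound 1 to compound 3 (0.20 log units; within the scatter) and so shows no separation between these mirror images. The earlier compounds shown here were drawn with the same configuration and could not speak to this change; here the comparison rests on configuration alone because of one fact: the fact that compounds 1 and 3 differ only in the configuration as drawn.

Still open, as far as these compounds go, is whether inverting only one of the two stereocentres would shift the number. Also open, from the compounds shown here alone, is whether mirror images would stay this close if the amine carried a benzyl group instead.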